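Methoxy on the Phenyl Arm of a Chalcone Imidazolone Series

The source may hold more compounds than are shown below. What is called first, only, known or untested is meant among the compounds shown, and "the series" means these compounds.

Compound 1 `COc1cc(/C=C/C(=O)c2cccc(-n3cc(-c4ccccc4)[nH]c3=O)c2)ccc1O` was tested in a functional assay on LOX IMVI cells (Homo sapiens) for inhibition (a higher number here means a weaker inhibitor of growth, a lower number a stronger inhibitor of growth), where compound 1 gives 1880 nM. Among the three compounds measured so far, compound 1 has the highest number, yet the gaps to the other two are small. Compound 2 `O=C(/C=C/c1cccc(O)c1)c1cccc(-n2cc(-c3ccccc3)[nH]c2=O)c1` gives 1850 nM, and the step of a 1.0-fold lower number from compound 1 to compound 2 (0.01 log units; within the scatter) lies within the scatter. Compound 3 `O=C(/C=C/c1cccc(O)c1)c1cccc(-n2cc(-c3ccc(Cl)cc3)[nH]c2=O)c1` gives 1570 nM, and the step of a 1.2-fold lower number from compound 2 to compound 3 (0.07 log units; within the scatter) also lies within the scatter. All three numbers therefore sit in one narrow band.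

Compound 4 `COc1ccc(-c2cn(-c3cccc(C(=O)/C=C/c4ccc(O)c(OC)c4)c3)c(=O)[nH]2)cc1` differs from compound 1 in one place: methoxy in place of hydrogen on an aromatic carbon. The closest comparison in the data is the change from compound 2 to compound 3, a substituent entering on the same phenyl ring on the shared core, which moved the number only within the scatter a 1.2-fold lower number from compound 2 to compound 3 (0.07 log units; within the scatter). The other step, at the far end of the chain a 1.0-fold lower number from compound 1 to compound 2 (0.01 log units; within the scatter), was likewise flat. On this basis the author expects the step of a 1.1-fold lower number from compound 1 to compound 4 (0.04 log units; within the scatter) to stay within the scatter, with no clear direction. Compound 4 is therefore estimated at 1700 nM, with a likely range from 900 nM to 3300 nM.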

Compound 4, concentration for 50% growth inhibition: 2440 nM
Estimate against measurement, compound 4: 1.4-fold (0.16 log units) below, and the stated range covers the measured number.
By their numbers in this assay, from the lowest: compounds 3, 2, 1 and 4 (each within the scatter of the next).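

In this assay, the methoxy that enters on the phenyl ring, on an aromatic carbon para to a large group, gives a 1.3-fold higher number from compound 1 to compound 4 (0.11 log units; within the scatter), so this replacement of hydrogen by a group of 2 heavy atoms leaves the number in the same narrow band as the other compounds. Among the compounds shown here, until now, the only change at this position was chloro, with a 1.2-fold lower number from compound 2 to compound 3 (0.07 log units; within the scatter), and that step was made with the 3-hydroxyphenyl arm; the new step shows that phenyl to 4-methoxyphenyl is also flat with the 4-hydroxy-3-methoxyphenyl arm, and since both steps lie within the scatter, neither gives a direction for substitution at this position. Nothing in the data shown accounts for this flat behaviour.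

Going by these compounds, whether an amine or a carboxylic acid at this same place would stay in the band remains open, as does the outcome for a longer chain such as butoxy. Also open, on these data alone, is how methoxy at this position would read with the 3-hydroxyphenyl arm, and how chloro would read with the 4-hydroxy-3-methoxyphenyl arm.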